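This account rests on a few compounds, and the source may have more. Where it says the series, first, only, none or still open, it means among the compounds named here.

Values so far in a functional assay on K562 cells (Homo sapiens) for inhibition, read by trypan blue exclusion, with a stated time of 72 h (on this read-out lower numbers stand for stronger inhibition and higher numbers for weaker inhibition), are these
compound 1 `Cn1c(=O)c(S(=O)(=O)c2ccc(F)cc2F)cc2cnc(Nc3ccc4occc4c3)nc21` gives 15000 nM
compound 2 `Cn1c(=O)c(S(=O)(=O)c2ccc(F)cc2F)cc2cnc(Nc3ccc4[nH]ncc4c3)nc21` gives 50000 nM
compound 3 `Cn1c(=O)c(S(=O)(=O)c2ccc(F)cc2F)cc2cnc(NCc3ccc4[nH]ccc4c3)nc21` gives 75000 nM

Compound 3 shares the high end of this short series with compound 2, as a 1.5-fold higher number from compound 2 to compound 3 (0.18 log units; within the scatter) shows, and stands clearly apart from compound 1, with a 5.0-fold higher number from compound 1 to compound 3 (0.70 log units; beyond the scatter) between them.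

Compound 4 `Cn1c(=O)c(S(=O)(=O)c2ccc(F)cc2F)cc2cnc(Nc3ccc4c(c3)C(=O)C(=O)N4)nc21` differs from compound 3 at one place: a group of 11 heavy atoms (8 carbon, 1 nitrogen, 2 oxygen; one five-membered non-aromatic ring with 1 hetero atom, one six-membered aromatic ring of carbon only) in place of a group of 10 heavy atoms (9 carbon, 1 nitrogen; one five-membered aromatic ring with 1 hetero atom, one six-membered aromatic ring of carbon only), on a nitrogen on an aromatic ring, and the rest of the molecule stays the same.

The guides are earlier swaps at this place, such as a 3.3-fold higher number from compound 1 to compound 2 (0.52 log units; beyond the scatter), which was modest. Compound 4 has no methyl link, like compound 2 at 50000 nM and compound 1 at 15000 nM, so a modest step to a lower number is expected. Within the data shown here, no measured compound carries the entering group, so the range stays wide.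

Estimated, this is a 2.5-fold lower number from compound 3 to compound 4 (0.40 log units; beyond the scatter) in size.

The estimate for compound 4 is 30000 nM, expected between 10000 nM and 90000 nM.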

Compound 4, half-maximal inhibitory concentration: 30000 nM
Compound 4: the middle estimate sits on the measured number at the digits printed; the range from low to high includes it.
By their numbers in this assay, from the lowest: compounds 1, 4, 2 and 3 (each within the scatter of the next, the first and the last beyond it).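

In this assay, the entering group, with its five-membered non-aromatic ring, shows that this place does not need two aromatic rings: a 1.7-fold lower number from compound 2 to compound 4 (0.22 log units; within the scatter) and a 2.0-fold higher number from compound 1 to compound 4 (0.30 log units; within the scatter) both stay within the scatter. A gap appears only against the (1H-indol-5-yl)methyl group, with a 2.5-fold lower number from compound 3 to compound 4 (0.40 log units; beyond the scatter). Nothing here bears on why the numbers fall as they do. As far as these compounds go, compound 1 gives 15000 nM, and still open is whether a phenyl ring carrying an amine or a carboxylic acid at this place would give a clearly lower number.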